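Moving the carboxyl around the ring: compound 3 to compound 4

A few compounds are considered here, and "the series" means these few. Any claim that something is new, unique, unknown or untested is made for them only; others in the source may bear on it.

Measured so far:
compound 1 `CN(Cc1ccc(C(=O)O)cc1)c1ccc(OCc2c(-c3c(Cl)cccc3Cl)noc2C2CC2)nc1C(F)(F)F`, 6 nM
compound 2 `CC(Nc1ccc(C(=O)O)cc1)c1ccc(OCc2c(-c3c(Cl)cccc3Cl)noc2C2CC2)nc1C(F)(F)F`, 202 nM
compound 3 `O=C(O)c1cccc(OCc2ccc(OCc3c(-c4c(Cl)cccc4Cl)noc3C3CC3)nc2C(F)(F)F)c1`, 33 nM

All three share one core and differ only in the acid-bearing arm. In a functional assay on HEK293 cells for agonist activity at Bile acid receptor (Homo sapiens), read by a luciferase reporter (a lower number here means that less compound is needed, a higher number that more compound is needed for the effect), compound 3 stands second of the three numbers: a 5.5-fold higher number from compound 1 to compound 3 (0.74 log units; beyond the scatter), while a 6.1-fold lower number from compound 2 to compound 3 (0.79 log units; beyond the scatter).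

Compound 4 `O=C(O)c1ccc(OCc2ccc(OCc3c(-c4c(Cl)cccc4Cl)noc3C3CC3)nc2C(F)(F)F)cc1` keeps every atom of compound 3 and rearranges one group: 4-carboxyphenyl in place of 3-carboxyphenyl on an oxygen on a saturated carbon. Compound 4 has not yet been measured in this assay.

Among the compounds with values here, none of the measured steps isolates this change. The steps of a 34-fold higher number from compound 1 to compound 2 (1.53 log units; beyond the scatter) and a 5.5-fold higher number from compound 1 to compound 3 (0.74 log units; beyond the scatter) each alter the linker together with the acid position, so they show how wide the arm's influence can be without saying which way this single shift will go. Compound 1, the lowest number seen, carries its carboxyl in the same ring position that compound 4 adopts, but through a different linker.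

The expectation for compound 4 is therefore a step of modest size at most, direction uncertain: a 1.7-fold lower number from compound 3 to compound 4 (0.22 log units; within the scatter). Compound 4 is estimated at 20 nM, within 4 nM to 100 nM.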

Compound 4, half-maximal effective concentration: 38 nM
The estimate for compound 4 lay 1.9-fold (0.28 log units) below the measured number; low and high end bracket the measured number.
By their numbers in this assay, from the lowest: compound 1; then compounds 3 and 4 (each within the scatter of the next); then compound 2.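

In this assay, the 3-carboxyphenyl and 4-carboxyphenyl placements on this oxygen-linked arm cannot be told apart: a 1.2-fold higher number from compound 3 to compound 4 (0.06 log units; within the scatter). The larger gaps appear only when the whole arm is exchanged, linker included, as in a 5.3-fold lower number from compound 2 to compound 4 (0.73 log units; beyond the scatter) and a 6.3-fold higher number from compound 1 to compound 4 (0.80 log units; beyond the scatter), so neither of these two steps isolates the carboxyl position. The data shown offer no measurement that would explain this result.

As far as these compounds go, it remains open whether the 3-carboxyphenyl and 4-carboxyphenyl placements would also be indistinguishable on the nitrogen-containing linkers of compound 1 and compound 2. The compounds shown also leave open how the oxygen-linked arm would respond to a tetrazole in place of the carboxylic acid, or to a longer chain between the oxygen and the ring.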